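Triazole series, cytotoxicity on PC-12 cells: compound 4

A few compounds are considered here, and "the series" means these few. Any claim that something is new, unique, unknown or untested is made for them only; others in the source may bear on it.

Three compounds share one core and differ only in the group on the ring nitrogen. In a functional assay on PC-12 cells (Rattus norvegicus) for cytotoxicity, read by MTT assay, with stated times of 2 h and 24 h, tested at 1 uM (on this read-out lower numbers stand for a weaker effect and higher numbers for a stronger effect at the one concentration tested), compound 1 `CC(C)c1ccc(-n2nc(-c3ccc(C(F)(F)F)cc3O)nc2-c2ccccc2O)cc1` gives 69.7%, compound 2 `Oc1cc(C(F)(F)F)ccc1-c1nc(-c2ccccc2O)n(-c2ccc(F)cc2)n1` gives 67.2%, and compound 3 `Oc1cc(C(F)(F)F)ccc1-c1nc(-c2ccccc2O)n(-c2ccc(I)cc2)n1` gives 70.1%. Compound 3 holds the highest of the three numbers, yet the steps of a number 0.4 percentage points higher from compound 1 to compound 3 (within the scatter) and a number 2.9 percentage points higher from compound 2 to compound 3 (within the scatter) are both within the scatter, as is a number 2.5 percentage points lower from compound 1 to compound 2 (within the scatter), so the three stand level.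

Compound 4 `Oc1cc(C(F)(F)F)ccc1-c1nc(-c2ccccc2O)n(-c2ccccc2C(F)(F)F)n1` carries the change (2-(trifluoromethyl)phenyl in place of 4-iodophenyl on an aromatic nitrogen). Among the compounds with values here, the measured steps all exchange one group on an aromatic carbon of that phenyl and none moved the read-out beyond the scatter; no measured step covers a change of this kind. A step of about a number 1.1 percentage points lower from compound 3 to compound 4 (within the scatter) is therefore expected, none beyond the scatter. Compound 4 is estimated at 69%, within 58% to 80%.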

Compound 4, a percentage reported as activity, at one concentration (the size of the read-out at that concentration, not a potency): 71%
The estimate for compound 4 lay 2 percentage points below the measured number; the range from low to high includes it.
By their numbers in this assay, from the lowest: compounds 2, 1, 3 and 4 (each within the scatter of the next).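

In this assay, 2-(trifluoromethyl)phenyl on the aromatic nitrogen stands level with 4-iodophenyl (a number 0.9 percentage points higher from compound 3 to compound 4 (within the scatter)), 4-fluorophenyl (a number 3.8 percentage points higher from compound 2 to compound 4 (within the scatter)) and 4-isopropylphenyl (a number 1.3 percentage points higher from compound 1 to compound 4 (within the scatter)). Across these four compounds, neither the group on the phenyl nor its place on that ring moved the read-out beyond the scatter. Nothing measured here speaks to why the read-out stays level.

From the compounds shown here alone, whether a phenyl carrying a carboxylic acid or an amine, or a plain alkyl chain in place of the phenyl, would leave the number level stays open. Going by these compounds, the shared core's two hydroxyl groups and its trifluoromethyl group also stay open, since they are constant in all four compounds.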